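The compounds below may be only part of what the source reports. "The series", "measured", "known", "first", "only" and "open" are said of these compounds alone.

Compound 1 `COc1ccc(/C=C/C(=O)c2ccccc2-c2cccc(F)c2)cc1OC` and compound 2 `COc1ccc(/C=C/C(=O)c2ccccc2-c2cccc(F)c2)cc1O` share a core, and in a functional assay on HepG2 cells (Homo sapiens) for antiproliferative activity, read by sulforhodamine B assay, with a stated time of 48 h (a higher number here means a weaker inhibitor, a lower number a stronger inhibitor), compound 1 gives 150 nM while compound 2 gives 8 nM. The change between them, (hydrogen in place of methyl on an oxygen on an aromatic ring), produced a 19-fold lower number from compound 1 to compound 2 (1.27 log units; beyond the scatter). Compound 3 `COc1ccc(C(=O)/C=C/c2ccccc2-c2ccc(F)cc2)cc1OC` has the same atoms as compound 1 joined differently; the difference between the two cores is not broken down here. In this assay compound 3 gives 6600 nM, the highest of the three numbers. Compound 4 `COc1cc(C(=O)/C=C/c2ccccc2-c2ccc(F)cc2)ccc1O` has not yet been measured in this assay; it differs from compound 3 by hydrogen in place of methyl on an oxygen on an aromatic ring, the same kind of change as from compound 1 to compound 2. Because compound 1 to compound 2 gave a 19-fold lower number from compound 1 to compound 2 (1.27 log units; beyond the scatter), compound 4 is expected to show a 9.4-fold lower number from compound 3 to compound 4 (0.97 log units; beyond the scatter), tempered since the core differs. The estimated value for compound 4 is 700 nM, within 150 nM to 3500 nM.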

Compound 4, half-maximal inhibitory concentration: 3100 nM
Estimate against measurement, compound 4: 4.4-fold (0.65 log units) below, and the stated range covers the measured number.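

On the core of compound 3, replacing methoxy with hydroxy again lowers the number in this assay, giving a 2.1-fold lower number from compound 3 to compound 4 (0.33 log units; beyond the scatter), so the direction of the change holds on both cores shown. The size of the change does not carry over, and the two steps differ by more than the scatter: the same change on two cores in this assay, a 19-fold lower number (1.27 log units; beyond the scatter) from compound 1 to compound 2 and a 2.1-fold lower number (0.33 log units; beyond the scatter) from compound 3 to compound 4, 8.8-fold (0.94 log units) apart, beyond the scatter of two such steps. Compound 1 and compound 3 have the same atoms joined differently, and these two pairs do not show which part of that difference goes with the gap, or what the change would do on a further core.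

Still open, as far as these compounds go, is how a longer chain on that oxygen, such as ethyl, would compare with methyl and hydrogen. An amine in place of the hydroxy also remains untested among the compounds shown.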